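Swapping a Methoxyphenyl Thioether for a Fluorophenyl Ether

The source may hold more compounds than are shown below. What is called first, only, known or untested is meant among the compounds shown, and "the series" means these compounds.

Two measured compounds share one core carrying two amine groups and a phenyl group. Compound 1 `CCOC(=O)[C@H](CCC(=O)O)NC(=O)c1ccc(Sc2nc3cc(N)cc(N)c3nc2-c2ccccc2)cc1` bears an amino-acid ester on its thioether arm, and in a functional assay on MDA-MB-231 cells (Homo sapiens) for inhibition, read by sulforhodamine B assay, with a stated time of 48 h (on this read-out higher numbers stand for weaker inhibition of growth and lower numbers for stronger inhibition of growth), compound 1 gives 7940 nM. Compound 2 `COc1ccc(Sc2nc3cc(N)cc(N)c3nc2-c2ccccc2)cc1` carries a (4-methoxyphenyl)sulfanyl group instead. In this assay compound 2 gives < 100000 nM, which is a limit of the measurement and not a number. Compound 2 thus stands at the limit of < 100000 nM in this assay, at which 1 of the 2 values shown sits, so its true position is not fixed by the data. Compound 3 `Nc1cc(N)c2nc(-c3ccccc3)c(Oc3ccc(F)cc3)nc2c1` has not been measured. The change is 4-fluorophenoxy in place of (4-methoxyphenyl)sulfanyl on an aromatic carbon. Among the compounds with values here, no measured step sets the size or direction of this change. The step from compound 2 to compound 3 is expected to be a step that the limit leaves unreadable from compound 2 to compound 3. Compound 3 is estimated at 25000 nM, within a range from 4000 nM to 100000 nM.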

Compound 3, concentration for 50% growth inhibition: 3890 nM
The estimate for compound 3 lay 6.4-fold (0.81 log units) above the measured number; measured number outside the range, below it.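

No step can be read from compound 2 to compound 3, because the value for compound 2 is a limit and not a number: the limit of < 100000 nM in this assay, at which 1 of the 3 values shown sits.

The compounds shown leave open how far, and in which direction, 4-fluorophenoxy in place of (4-methoxyphenyl)sulfanyl shifts growth inhibition.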